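This account rests on a few compounds, and the source may have more. Where it says the series, first, only, none or still open, it means among the compounds named here.

Compound 1 (`CS(=O)(=O)N1CCC2(CC1)OOC1(CCN(S(C)(=O)=O)CC1)OO2`) gives > 100 ug/mL as a limit
Compound 2 (`CS(=O)(=O)N1CCC2(CC1)OOC1(CCCCC1)OO2`) gives > 100 ug/mL as a limit
Compound 3 (`CCCS(=O)(=O)N1CCC2(CC1)OOC1(CCCCCC1)OO2`) gives > 100 ug/mL as a limit

In a functional assay on Huh-7 cells (Homo sapiens) for cytotoxicity, read by MTT assay, with a stated time of 72 h (on this read-out lower numbers stand for higher toxicity in this test and higher numbers for lower toxicity in this test), the three compounds share one reading, the limit of > 100 ug/mL in this assay, at which 3 of the 3 values shown sit, and none of them carries a number. Compound 2 gives > 100 ug/mL and this is a limit, not a number. The change to compound 4 (`Cc1ccc(S(=O)(=O)N2CCC3(CC2)OOC2(CCCCC2)OO3)cc1`) is 4-methylphenyl in place of methyl on a sulfonyl sulfur and it puts 4-methylphenyl in place of methyl on a sulfonyl sulfur. Among the measured compounds shown here, no measured compound carries an aromatic ring there. The expectation of no step beyond the usual scatter in this assay rests on compound 3, which gives > 100 ug/mL and this too is a limit. Any shift would be expected toward lower numbers. The estimated change is a number no higher from compound 2 to compound 4 (the limit leaves the size open) and it remains only an expectation. For compound 4 the estimate is 100 ug/mL with an expected range from 40 ug/mL to 150 ug/mL in this test.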

Compound 4, half-maximal cytotoxic concentration: > 100 ug/mL
Compound 4 ended at the assay's limit; the forecaster's own chance of this, stated with the estimate: 65%; the middle value sits exactly at the limit.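

No step can be read from compound 2 to compound 4, as both values are limits and not numbers: the limit of > 100 ug/mL in this assay, at which 4 of the 4 values shown sit.

The compounds shown leave open whether 4-methylphenyl and methyl on the sulfonyl sulfur differ at all in this test.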